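Aryl variation at the thioether carbon: compound 3 to compound 4

The compounds below may be only part of what the source reports. "The series", "measured", "known", "first", "only" and "open" are said of these compounds alone.

Measured compounds:
compound 1 `CC(Sc1nc2c(cnn2C)c(=O)n1-c1ccccc1)c1cccc(F)c1` gives 151 nM in an assay on isolated protein for inhibition of aldehyde dehydrogenase 1A1 (Homo sapiens); a lower number here means a stronger inhibitor, a higher number a weaker inhibitor
compound 2 `CC(Sc1nc2c(cnn2C)c(=O)n1-c1ccccc1)c1ccccc1` gives 130 nM in this assay
compound 3 `COc1ccccc1C(C)Sc1nc2c(cnn2C)c(=O)n1-c1ccccc1` gives 445 nM in this assay

Compound 3 carries the highest number of the three. Its nearest neighbour is compound 1, with a 2.9-fold higher number from compound 1 to compound 3 (0.47 log units; beyond the scatter); its furthest is compound 2, with a 3.4-fold higher number from compound 2 to compound 3 (0.53 log units; beyond the scatter). Between compounds 1 and 2 the step is a 1.2-fold lower number from compound 1 to compound 2 (0.07 log units; within the scatter), so these two cannot be ordered.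

Compound 4 `CC(Sc1nc2c(cnn2C)c(=O)n1-c1ccccc1)c1cncnc1` follows from compound 3 by pyrimidin-5-yl in place of 2-methoxyphenyl on a saturated chain carbon bound to a saturated chain carbon and a sulfur. The step bearing most directly on it is a 3.4-fold higher number from compound 2 to compound 3 (0.53 log units; beyond the scatter), which shows that the methoxy in compound 3 raised the number by a modest amount; taking the methoxy away again should return the number toward the level of compound 2. Among the compounds with values here, no measured step covers the exchange of a carbon-only ring for a ring with two hetero atoms, so that part is unsupported. The expected step is therefore a modest drop, a 2.5-fold lower number from compound 3 to compound 4 (0.39 log units; beyond the scatter), with a wide range. Compound 4 is estimated at 180 nM in this assay, between 70 nM and 500 nM.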

Compound 4, half-maximal inhibitory concentration: 94 nM
Compound 4: middle estimate off by 1.9-fold (0.28 log units), on the high side; low and high end bracket the measured number.
By their numbers in this assay, from the lowest: compounds 4, 2 and 1 (each within the scatter of the next); then compound 3.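

In this assay, the saturated chain carbon bound to a saturated chain carbon and a sulfur accepts a ring with two hetero atoms, which the earlier carbon-only rings could not show: pyrimidin-5-yl cannot be told apart from phenyl (a 1.4-fold lower number from compound 2 to compound 4 (0.14 log units; within the scatter)) or from 3-fluorophenyl (a 1.6-fold lower number from compound 1 to compound 4 (0.21 log units; within the scatter)). The larger step away from 2-methoxyphenyl (a 4.7-fold lower number from compound 3 to compound 4 (0.68 log units; beyond the scatter)) therefore brings no gain over phenyl, and among these four compounds only compound 3 stands apart. No measurement at hand accounts for these results.

Open, going by these compounds, is whether an amine or a carboxylic acid on this ring would hold the number at this level. Also open, on these data alone, is whether a pyridyl ring or a longer chain in place of the ring would do so.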